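Hydroxy on compound 3: working notes

A few compounds are considered here, and "the series" means these few. Any claim that something is new, unique, unknown or untested is made for them only; others in the source may bear on it.

Going by the values given here, in a functional assay on cells (Cancer cell lines, Homo sapiens) for inhibition, with a stated time of 48 h (a lower number here means a stronger inhibitor of growth, a higher number a weaker inhibitor of growth), compound 3 (`COc1cc2c(/C=C3/C(=O)N(C)c4ccccc43)c[nH]c2cc1C`) gives 60300 nM, the highest of the three numbers so far. Compound 1 (`COc1cc2c(/C=C3/C(=O)Nc4ccc(Br)cc43)c(Cl)[nH]c2cc1C`) gives 6760 nM and compound 2 (`COc1ccc2c(c1)/C(=C\c1c(Cl)[nH]c3ccc(N(C)C)cc13)C(=O)N2`) gives 9550 nM. Both of these differ from compound 3 in more than one place, so neither isolates a single change.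

Compound 4 (`COc1cc2c(/C=C3/C(=O)N(C)c4ccc(O)cc43)c[nH]c2cc1C`) is compound 3 with hydroxy in place of hydrogen on an aromatic carbon. Among the compounds with values here, no measured pair shows this change, so the size of the step is poorly constrained. A moderate fall in the number is expected, resting only on the top position of compound 3 at 60300 nM, which leaves more room downward than upward. The estimated change is a 2.2-fold lower number from compound 3 to compound 4 (0.33 log units; beyond the scatter), and a result within the scatter would not be surprising. For compound 4 the estimated value is 28000 nM, with an expected range of 8000 nM to 80000 nM.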

Compound 4, concentration for total growth inhibition: 24600 nM
Estimate against measurement, compound 4: 1.1-fold (0.06 log units) above; the range from low to high includes it.
By their numbers in this assay, from the lowest: compounds 1 and 2 (each within the scatter of the next); then compound 4; then compound 3.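

In this assay the series now has its first step at a single place, a 2.5-fold lower number from compound 3 to compound 4 (0.39 log units; beyond the scatter), and that step comes from hydroxy in place of hydrogen on an aromatic carbon. The earlier compounds shown here could not show this, as they differ from one another in more than one place. The position therefore accepts a hydroxy group with a modest fall in the number rather than a rise, though one substituent at one position gives no trend. Nothing at hand accounts for the size of this step.

On these data alone, whether an amine or a carboxylic acid on the same aromatic carbon would lower the number further, match hydroxy or raise the number remains open. Also open, as far as these compounds go, is whether the hydroxy step would carry over to a compound with the amide hydrogen in place of the methyl group.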